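Swapping the Sulfur-Linked Heterocycle in a Cytotoxicity Series

The source may report more compounds than this note shows. Statements on the series, on what has been measured and on what is new or still open speak of the compounds shown alone.

Compound 1 `Cc1nnc(SCC(=O)N/N=c2/scc(-c3ccccc3)n2-c2ccccc2)s1`: 65.9%
Compound 2 `Cc1ccc(-c2cs/c(=N/NC(=O)CSc3nncn3C)n2-c2ccccc2)cc1`: 70.7%
Compound 3 `Cn1cnnc1SCC(=O)N/N=c1/scc(-c2ccc(C#N)cc2)n1-c1ccccc1`: 58.8%

Of the compounds shown here, three sharing one core have been measured in a functional assay on C6 cells (Rattus norvegicus) for cytotoxicity, read by MTT assay, with a stated time of 24 h, tested at 25 ug/mL; on this read-out higher numbers stand for a weaker effect at the one concentration tested and lower numbers for a stronger effect. Compound 2 stands at the top of the three numbers, but compound 1 lies within the usual scatter of it, while compound 3 lies beyond it. Among the compounds with values here, compound 1 differs from compound 2 in two places at once, so its value shows only that a thiadiazolyl-bearing compound of this core is not far from compound 2.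

The step now followed leads to compound 4 `Cc1ccc(-c2cs/c(=N/NC(=O)CSc3nnc(C)s3)n2-c2ccccc2)cc1`, which differs from compound 2 in this way: 5-methyl-1,3,4-thiadiazol-2-yl in place of 4-methyl-4H-1,2,4-triazol-3-yl on a sulfur. Within the data shown here, the only measured step, a number 11.9 percentage points lower from compound 2 to compound 3 (beyond the scatter), concerns the aryl substituent and not the sulfur-linked heterocycle, so no measured step bears directly on this change. The values of compound 1 and compound 2, which carry the two heterocycles in question, fall within the scatter of each other. On this basis no step beyond the scatter is expected in this assay, and the change from compound 2 to compound 4 is estimated at a number 2.7 percentage points lower from compound 2 to compound 4 (within the scatter). Compound 4 is therefore expected to give 68%, within a range from 58% to 78%.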

Compound 4, a percentage reported as activity, at one concentration (the size of the read-out at that concentration, not a potency): 50.1%
The estimate for compound 4 lay 17.9 percentage points above the measured number; measured number outside the range, below it.
By their numbers in this assay, from the lowest: compounds 4, 3, 1 and 2 (each within the scatter of the next, the first and the last beyond it).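

With the methyl on the aromatic carbon kept in place, 5-methyl-1,3,4-thiadiazol-2-yl in place of 4-methyl-4H-1,2,4-triazol-3-yl on a sulfur gives in this assay a number 20.6 percentage points lower from compound 2 to compound 4 (beyond the scatter) and thus a stronger effect at the one concentration tested, so the heterocycle at this position matters even though the two groups have the same counts of heavy atoms and hydrogen-bond acceptors. With the thiadiazolyl group held constant, methyl in place of hydrogen on an aromatic carbon gives a number 15.8 percentage points lower from compound 1 to compound 4 (beyond the scatter) in the same assay, a change that the closeness of the values of compound 1 and compound 2 had not revealed. Nothing shown here explains why either change has this effect.

From the compounds shown here alone, it remains open whether the same heterocycle swap would also lower the number when the aryl group carries the nitrile of compound 3 rather than a methyl. Going by these compounds, the effect of an amine or an ethyl chain in place of the methyl on the thiadiazole ring also remains open, as does whether these differences would hold at other concentrations.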